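This account rests on a few compounds, and the source may have more. Where it says the series, first, only, none or still open, it means among the compounds named here.

Compound 1 `O=[N+]([O-])c1cn2c(n1)OC[C@H](OCc1ccc(-c3ccc(OC(F)(F)F)cc3Cl)cc1)C2` was examined in an ADME assay on L6 cells (Rattus norvegicus) for cytotoxicity, read by resazurin assay, with a stated time of 72 h (on this read-out lower numbers stand for stronger inhibition and higher numbers for weaker inhibition), where compound 1 gives 25000 nM. Its companion compound 2 `O=[N+]([O-])c1cn2c(n1)OC[C@H](OCc1ccc(-c3ccc(C(F)(F)F)cc3Cl)cn1)C2` gives 50000 nM in this assay; the two numbers sit within the usual scatter of each other, so compound 1 cannot be set apart from compound 2 on this read-out. Compound 3 `O=[N+]([O-])c1cn2c(n1)OC[C@H](OCc1ccc(-c3ccc(C(F)(F)F)cc3Cl)cc1)C2` has not been measured yet. Against compound 1 it carries a single change: trifluoromethyl in place of trifluoromethoxy on an aromatic carbon. Within the data shown here, no measured pair shows this change. In this assay no shift beyond the scatter is expected from it, in either direction. For compound 3 the expected reading is 25000 nM, in a range from 10000 nM to 60000 nM, which would mean an expected step of no change at the digits printed from compound 1 to compound 3 (within the scatter).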

Compound 3, half-maximal inhibitory concentration in the L6 assay: 29000 nM
Compound 3: middle estimate off by 1.2-fold (0.06 log units), on the low side; measured number inside the range.
By their numbers in the L6 assay, from the lowest: compounds 1, 3 and 2 (each within the scatter of the next).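

In the L6 assay, trifluoromethyl in place of trifluoromethoxy on this aromatic carbon gives a 1.2-fold higher number from compound 1 to compound 3 (0.06 log units; within the scatter), within the scatter, so this first direct test of the change leaves the two compounds indistinguishable on this read-out. In a physicochemical assay for solubility, read by HPLC, measured as kinetic solubility, with a stated time of 15 min (a lower number here means a less soluble compound, a higher number a more soluble compound), compound 1 gives < 0.1 ug/mL, which is a limit of the assay. In the physicochemical assay compound 3 gives < 0.1 ug/mL, also a limit, so no step can be read here: the limit of < 0.1 ug/mL in the physicochemical assay, at which 2 of the 2 values shown sit.

On these data alone, it remains open whether an amine or a carboxylic acid at this position would shift the reading in the L6 assay or give a number rather than a limit in the physicochemical assay.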